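A few compounds are considered here, and "the series" means these few. Any claim that something is new, unique, unknown or untested is made for them only; others in the source may bear on it.

In a functional assay on DU-145 cells (Homo sapiens) for cytotoxicity, read by MTT assay (on this read-out higher numbers stand for weaker inhibition and lower numbers for stronger inhibition), compound 1, whose structure is `CC(O)(CSc1ccccc1)c1nc(-c2ccc([N+](=O)[O-])c(C(F)(F)F)c2)no1`, gives 3000 nM. Within the data shown here, this is the only number in this assay, the one other result being a limit. Compound 2, with the structure `CC(O)(CS(=O)(=O)c1ccccc1)c1nc(-c2ccc(Cl)cc2)no1`, reaches only > 100000 nM, which is a limit of the assay rather than a measured number; compound 2 sits at the limit of > 100000 nM in this assay, at which 1 of the 2 values shown sits. Among the measured compounds shown here, no single-point step between measured compounds is available, since compound 2 differs from compound 1 in more than one place.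

Compound 3, with the structure `CC(O)(CS(=O)(=O)c1ccccc1)c1nc(-c2ccc([N+](=O)[O-])c(C(F)(F)F)c2)no1`, has not yet been measured. Compared with compound 1 it carries phenylsulfonyl in place of phenylsulfanyl on a saturated chain carbon, two bonds along the chain from an aromatic carbon and an oxygen on a saturated carbon. Compound 2 carries the same phenylsulfonyl group and sits at the limit. Compound 3 is expected to be weaker than compound 1, with an expected step of a 5.0-fold higher number from compound 1 to compound 3 (0.70 log units; beyond the scatter) in this assay. Compound 3 is therefore estimated at 15000 nM, in a range from 3000 nM to 100000 nM, with a real chance that only a limit is returned.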

Compound 3, half-maximal inhibitory concentration: > 100000 nM
Compound 3: no number, only a limit; the forecaster's own chance of this, stated with the estimate: 30%; at least 6.6-fold (0.82 log units) between middle value and limit.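

With the core of compound 1 otherwise unchanged, placing phenylsulfonyl instead of phenylsulfanyl on this saturated chain carbon gives an at least 33-fold higher number from compound 1 to compound 3 (1.52 log units; beyond the scatter) in this assay. This single change is enough to take the cytotoxicity of compound 1 out of the measurable range, which compound 2 could not show, as it differs from compound 1 in more than one place. Compound 3 gives > 100000 nM, which is a limit of the assay and not a number, so the full size of the step remains unknown, and compound 3 stands at the same place as compound 2: the limit of > 100000 nM in this assay, at which 2 of the 3 values shown sit.

The compounds shown do not tell why this change has so large an effect. They also leave open whether phenylsulfinyl or phenoxy at this position would retain measurable cytotoxicity.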